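The compounds below may be only part of what the source reports. "The series", "measured", "known", "first", "only" and "open" are said of these compounds alone.

Within the data shown here, compound 1 `CC(C)(CNC(=O)c1ccc2ccccc2c1)CC1=C(O)C(=O)c2ccccc2C1=O` stands at 28200 nM in a functional assay on MCF7 cells (Homo sapiens) for cytotoxicity, read by resazurin assay, with a stated time of 3 days (a higher number here means a weaker inhibitor, a lower number a stronger inhibitor), and holds the lower of the two numbers measured so far. On the same core, compound 2 `CC(C)(CNC(=O)c1ccc2ccccc2c1O)CC1=C(O)C(=O)c2ccccc2C1=O` reads 79500 nM in this assay and the comparison rests on this pair alone. Compound 3 `COc1ccccc1C(=O)NCC(C)(C)CC1=C(O)C(=O)c2ccccc2C1=O` differs from compound 1 by a larger change: 2-methoxyphenyl in place of naphthalen-2-yl on a carbonyl carbon with 2-methoxyphenyl in place of naphthalen-2-yl on a carbonyl carbon. Among the measured compounds shown here, only one measured step bears on this, and it bears indirectly, as hydroxy in place of hydrogen on an aromatic carbon of the group that compound 3 replaces. For the measured compounds named here, no measured compound carries methoxy, and none has lost an aromatic ring. Going by the values given here, from the one available step (a 2.8-fold higher number from compound 1 to compound 2 (0.45 log units; beyond the scatter)) a modest rise is expected in this assay with the direction only weakly supported. The expected step is a 2.1-fold higher number from compound 1 to compound 3 (0.33 log units; beyond the scatter) and a larger or smaller one would not be surprising. For compound 3 the estimated value is 60000 nM with a range of 22000 nM to 150000 nM expected.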

Compound 3, half-maximal inhibitory concentration: 111000 nM
Compound 3: middle estimate off by 1.9-fold (0.27 log units), on the low side, and the stated range covers the measured number.
By their numbers in this assay, from the lowest: compound 1; then compounds 2 and 3 (each within the scatter of the next).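

In this assay, among these compounds, the change at the carbonyl carbon bonded to the amide-type nitrogen gives a 3.9-fold higher number from compound 1 to compound 3 (0.60 log units; beyond the scatter), the first step here that replaces the whole naphthalen-2-yl group rather than adding to it: 2-methoxyphenyl enters with one six-membered aromatic ring of carbon only in place of two, and with one hydrogen-bond acceptor where naphthalen-2-yl has none. Compound 1 now holds the lowest number against both other compounds with each step beyond the scatter, while compound 2 at 79500 nM and compound 3 at 111000 nM lie within the scatter of each other, so this assay does not separate these two changes to the naphthalen-2-yl compound. Nothing available gives a reason for the step from naphthalen-2-yl to 2-methoxyphenyl.

The loss of an aromatic ring and the entry of methoxy arrive together in compound 3, and only a phenyl without methoxy on this carbonyl carbon would tell the two apart. Going by these compounds, whether an amine or a carboxylic acid on the aromatic group would bring the number below that of compound 1 remains open.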